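This account rests on a few compounds, and the source may have more. Where it says the series, first, only, none or still open, it means among the compounds named here.

Working notes on the series.

Compound 1, `C/C(=C\c1cc(-c2ccccc2)cs1)C(N)=O`, is the parent of the set. In a functional assay on T-24 cells (Homo sapiens) for cytotoxicity, read by CCK-8 assay, with a stated time of 24 h (on this read-out higher numbers stand for weaker inhibition and lower numbers for stronger inhibition), compound 1 gives only a limit, > 50000 nM. Compound 2, `C/C(=C\c1cc(-c2ccc(C)cc2)cs1)C(N)=O`, carries a methyl on the aromatic carbon; in this assay compound 2 likewise gives only a limit, > 50000 nM. Compound 3, `C/C(=C\c1cc(-c2ccc(C#N)cc2)cs1)C(N)=O`, carries a cyano at that position. In this assay compound 3 stands at a limit as well, > 50000 nM. All three values sit at the limit of > 50000 nM in this assay, at which 3 of the 3 values shown sit, so the steps a step that the two limits leave unreadable from compound 1 to compound 2, a step that the two limits leave unreadable from compound 1 to compound 3 and a step that the two limits leave unreadable from compound 2 to compound 3 are unreadable in size and direction.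

Compound 4, `C/C(=C\c1cc(-c2ccc([N+](=O)[O-])cc2)cs1)C(N)=O`, differs from compound 3 by nitro in place of cyano on an aromatic carbon. Going by the values given here, the only measured steps that bear on a change at this position, from compound 1 or compound 2 to compound 3, give no readable size, so no direction beyond the scatter can be derived for compound 4. The expectation is that compound 4 remains at the limit; the estimate is 60000 nM, with a range from 15000 nM to 250000 nM. This estimate corresponds to an expected step that the limit leaves unreadable from compound 3 to compound 4.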

Compound 4, half-maximal inhibitory concentration: > 50000 nM
Compound 4 gave a limit, no number (the forecaster's own chance of this, stated with the estimate: 75%); the middle value lies beyond the limit too.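

Compound 4 joins compound 1, compound 2 and compound 3 at a limit, so no step among these compounds can be read: the limit of > 50000 nM in this assay, at which 4 of the 4 values shown sit.

The compounds shown leave open whether hydrogen, methyl, cyano or nitro at this position makes any difference to the read-out.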